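The source may report more compounds than this note shows. Statements on the series, on what has been measured and on what is new or still open speak of the compounds shown alone.

Compound 1 `O=C(O)/C=C/c1ccncc1-c1ccc2cc[nH]c2c1`: 103%
Compound 2 `COc1ccc(-c2cnccc2/C=C/C(=O)N2CC(OC)C2)cc1OC`: 87%
Compound 3 `CNC(=O)CCc1ccncc1-c1ccc2ccccc2c1`: 100%

In an assay on a protein complex for inhibition of CDK8/Cyclin C (Homo sapiens), with a stated time of 1 h, tested at 10 uM (a lower number here means less inhibition, a higher number more inhibition at the concentration tested (going by the name of the read-out)), compound 3 stands second highest of the three numbers. Its nearest neighbour is compound 1, which lies slightly higher, within the scatter, so no order between these two can be read. Compound 2 lies lower than compound 3 by a gap beyond the scatter. Compound 4 `O=C(O)/C=C/c1ccncc1-c1ccc2ccccc2c1` has not yet been measured. It differs from compound 3 in one place: 2-carboxyethenyl in place of 2-(methylcarbamoyl)ethyl on an aromatic carbon. Going by the values given here, no measured pair here carries the same change, so its effect cannot be read from these compounds. The other compound bearing a 2-carboxyethenyl group is compound 1, and compound 1 gives 103%, which is within the scatter of compound 3. A step of no change at the digits printed from compound 3 to compound 4 (within the scatter) is therefore expected, none beyond the scatter. Compound 4 is estimated at 100%, with a range from 88% to 108%.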

Compound 4, a percentage reported as inhibition, at one concentration (the size of the read-out at that concentration, not a potency): 102%
Compound 4: middle estimate off by 2 percentage points, on the low side; the range from low to high includes it.
By their numbers in this assay, from the lowest: compound 2; then compounds 3, 4 and 1 (each within the scatter of the next).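

In this assay, going by these compounds alone, 2-carboxyethenyl in place of 2-(methylcarbamoyl)ethyl on this aromatic carbon gives a number 2 percentage points higher from compound 3 to compound 4 (within the scatter), the first direct reading of a change at this position. At this single concentration, the position therefore accepts either group on the shared core without a readable difference. No evidence given here explains this result. The compounds shown leave open whether the carboxylic acid or the chain's double bond alone would give the same reading, since the step changes both. Going by these compounds, how an amine or a longer chain at this position would read also remains open.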